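Azole replacement on the amide-side arm of the series

This account rests on a few compounds, and the source may have more. Where it says the series, first, only, none or still open, it means among the compounds named here.

Measured compounds:
- compound 1, `CCN(Cc1nccs1)C(=O)COc1ccc(C)cc1`: 3060 nM in an assay on HEK293 cells for agonist activity at transient receptor potential cation channel subfamily M member 8 (Homo sapiens), read by fluorescence and calcium flux, with a stated time of 15 min; on this read-out lower numbers stand for an effect already at smaller amounts and higher numbers for an effect only at larger amounts of compound
- compound 2, `CCN(C(=O)COc1ccc(C)cc1)C(C)c1cccs1`: "not active" (no number reported) in this assay
- compound 3, `CCN(Cc1cc[nH]n1)C(=O)COc1ccc(C)cc1`: "not active" (no number reported) in this assay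

Among the measured compounds shown here, compound 1 is the only member of the series with a number; in this assay compound 1 gives 3060 nM. Compound 2 in this assay is reported as "not active" (no number reported), with no number given. Compound 3 in this assay is likewise reported as "not active" (no number reported), again without a number, so it stands among the two entries that carry no single value, and no ordering against compound 1 can be drawn beyond the fact that compound 1 has a measurable value and compound 3 does not.

Compound 4, `CCN(Cc1c[nH]nn1)C(=O)COc1ccc(C)cc1`, has not yet been measured. It differs from compound 3 as follows: 1H-1,2,3-triazol-4-yl in place of 1H-pyrazol-3-yl on a saturated chain carbon bound to an amide-type nitrogen. For the measured compounds named here, no measured pair shows this kind of change, so the size of the step in this assay cannot be read from data; with compound 3 carrying no number, any expectation must be loose, and the likeliest outcome is that compound 4 also returns no number or only a weak one. Compound 4 is estimated at 15000 nM, with an expected range from 3000 nM to 60000 nM.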

Compound 4, half-maximal effective concentration: 31100 nM
For compound 4 the middle estimate is 2.1-fold (0.32 log units) below the measured one; the measured number falls inside the stated range.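

In this assay, compound 4 puts a number on an azole carrying a hydrogen on a ring nitrogen, where compound 3, with 1H-pyrazol-3-yl at the same place, returned none, so this arm does not lose all response with such a ring. Set against the 1,3-thiazol-2-yl arm, 1H-1,2,3-triazol-4-yl on a saturated chain carbon bound to an amide-type nitrogen gives a 10-fold higher number from compound 1 to compound 4 (1.01 log units; beyond the scatter), the first step size read at this position. Compound 3 has no number, so its step to compound 4 cannot be read, and no measurement at hand bears on the result.

From the compounds shown here alone, whether a 1,3-oxazol-2-yl group or a plain phenyl ring at this place would sit closer to compound 1 stays open. Also open, going by these compounds, is whether any group here can improve on compound 1 at 3060 nM.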